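Nitrophenylsulfonyl seven-membered ring series: uracil and thymine variants

This account rests on a few compounds, and the source may have more. Where it says the series, first, only, none or still open, it means among the compounds named here.

Measured compounds:
compound 1, `Cc1cn(C2CN(S(=O)(=O)c3ccccc3[N+](=O)[O-])c3ccccc3CO2)c(=O)[nH]c1=O`, 45200 nM
compound 2, `O=c1cc[nH]c(=O)n1C1CN(S(=O)(=O)c2ccccc2[N+](=O)[O-])c2ccccc2CO1`, 50900 nM
compound 3, `Cc1cn(C2CN(S(=O)(=O)c3ccc([N+](=O)[O-])cc3)c3ccccc3CO2)c(=O)[nH]c1=O`, 39800 nM

In a functional assay on MCF7 cells (Homo sapiens) for cytotoxicity, read by sulforhodamine B assay, with a stated time of 3 days (on this read-out lower numbers stand for stronger inhibition and higher numbers for weaker inhibition), compound 1 gives 45200 nM, compound 2 gives 50900 nM and compound 3 gives 39800 nM. All three numbers sit close together. The change from compound 1 to compound 2 is a group of 8 heavy atoms (4 carbon, 2 nitrogen, 2 oxygen; one six-membered aromatic ring with 2 hetero atoms) in place of a group of 9 heavy atoms (5 carbon, 2 nitrogen, 2 oxygen; one six-membered aromatic ring with 2 hetero atoms), on a saturated ring carbon, and it made a 1.1-fold higher number from compound 1 to compound 2 (0.05 log units; within the scatter). The cores of compound 1 and compound 3 differ by 4-nitrophenyl in place of 2-nitrophenyl on a sulfonyl sulfur, which made a 1.1-fold lower number from compound 1 to compound 3 (0.06 log units; within the scatter).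

Compound 4, `O=c1cc[nH]c(=O)n1C1CN(S(=O)(=O)c2ccc([N+](=O)[O-])cc2)c2ccccc2CO1`, has not been measured in this assay. It differs from compound 3 by a group of 8 heavy atoms (4 carbon, 2 nitrogen, 2 oxygen; one six-membered aromatic ring with 2 hetero atoms) in place of a group of 9 heavy atoms (5 carbon, 2 nitrogen, 2 oxygen; one six-membered aromatic ring with 2 hetero atoms), on a saturated ring carbon. This is the same change as that from compound 1 to compound 2, made at the same place on the seven-membered ring, only on the core of compound 3 instead of the core of compound 1. Among the compounds with values here, since the earlier step was a 1.1-fold higher number from compound 1 to compound 2 (0.05 log units; within the scatter), the step from compound 3 to compound 4 is expected to be of the same small kind, namely a 1.1-fold higher number from compound 3 to compound 4 (0.04 log units; within the scatter), resting on the single measured pair. Compound 4 is therefore estimated at 44000 nM in this assay, with a likely range from 20000 nM to 95000 nM.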

Compound 4, half-maximal inhibitory concentration: 44300 nM
The estimate for compound 4 lay 1.0-fold (0.00 log units) below the measured number; the range from low to high includes it.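

In this assay, uracil in place of thymine on the core of compound 3 gave a 1.1-fold higher number from compound 3 to compound 4 (0.05 log units; within the scatter), which matches the step on the other core: the same change on two cores in this assay, a 1.1-fold higher number (0.05 log units; within the scatter) from compound 1 to compound 2 and a 1.1-fold higher number (0.05 log units; within the scatter) from compound 3 to compound 4, 1.0-fold (0.01 log units) apart, within the scatter of two such steps

Likewise, 4-nitrophenyl in place of 2-nitrophenyl gave a 1.1-fold lower number from compound 2 to compound 4 (0.06 log units; within the scatter), which matches the earlier step: the same change on two cores in this assay, a 1.1-fold lower number (0.06 log units; within the scatter) from compound 1 to compound 3 and a 1.1-fold lower number (0.06 log units; within the scatter) from compound 2 to compound 4, 1.0-fold (0.01 log units) apart, within the scatter of two such steps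

Within the data shown here, both changes therefore carried from one core to the other without any gap beyond the scatter, but all four steps are themselves within the scatter, so this shows only that neither change moved the number measurably on these two cores, not that a larger effect would carry over in the same way.

All four compounds share one core and differ only in thymine or uracil and in the 2-nitrophenyl or 4-nitrophenyl group. As far as these compounds go, it remains open whether an amine or a carboxylic acid in place of the nitro group, or adenine in place of uracil, would give a step beyond the scatter.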